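Methoxy on the benzylic chain carbon of an aryl urea

The compounds below may be only part of what the source reports. "The series", "measured", "known", "first", "only" and "open" are said of these compounds alone.

Compound 1 `O=C(NCCCCl)Nc1ccc(I)cc1`: > 100000 nM
Compound 2 `CCCCCc1cccc(NC(=O)NCCCCl)c1`: 24000 nM

In a functional assay on M21 cells (Homo sapiens) for antiproliferative activity, with a stated time of 48 h (a lower number here means a stronger inhibitor, a higher number a weaker inhibitor), compound 1 gives only a limit of the assay, > 100000 nM. Compound 2 gives 24000 nM in this assay, the only real number shown. The other value, that of compound 1, is a limit (the limit of > 100000 nM in this assay, at which 1 of the 2 values shown sits). Compound 3 `CCCCC(OC)c1cccc(NC(=O)NCCCCl)c1` differs from compound 2 by methoxy in place of hydrogen on a saturated chain carbon bound to an aromatic carbon and a saturated chain carbon. Among the measured compounds shown here, no measured step covers this change, so the expected step of a 1.3-fold higher number from compound 2 to compound 3 (0.10 log units; within the scatter) is a small one, if anything toward weaker inhibition, hardly beyond the scatter. For compound 3 the estimated value in this assay is 30000 nM, within a range from 8000 nM to 120000 nM.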

Compound 3, half-maximal inhibitory concentration: 51000 nM
For compound 3 the middle estimate is 1.7-fold (0.23 log units) below the measured one, and the stated range covers the measured number.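

Replacing hydrogen with methoxy on the saturated chain carbon, which turns pentyl into 1-methoxypentyl, gives in this assay a 2.1-fold higher number from compound 2 to compound 3 (0.33 log units; beyond the scatter). The change therefore leads to modestly weaker inhibition, and compound 3 still gives a real number rather than a limit. No measured property shown accounts for this step.

The compounds shown leave open whether a hydroxyl group or an amine on this same carbon would behave like methoxy. They also leave open whether an ethoxy group would weaken inhibition further.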